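Swapping a propyl for a chloro on a benzamide series

A few compounds are considered here, and "the series" means these few. Any claim that something is new, unique, unknown or untested is made for them only; others in the source may bear on it.

Measured compounds:
Compound 1 `Nc1cc(F)ccc1NC(=O)c1ccc(COc2ccccc2)cc1`: 6020 nM
Compound 2 `O=C(NO)c1ccc(COc2ccccc2)cc1`: "not determined" (no result reported)
Compound 3 `CCCc1ccc(OCc2ccc(C(=O)Nc3ccccc3N)cc2)cc1`: 4420 nM

In a functional assay on MGC-803 cells (Homo sapiens) for antiproliferative activity, read by CCK-8 assay, with a stated time of 72 h (on this read-out higher numbers stand for weaker inhibition and lower numbers for stronger inhibition), compound 1 gives 6020 nM. Compound 2 carries a hydroxamic acid in place of the aminoanilide and has no number in this assay; its result is "not determined" (no result reported). Compound 3 gives 4420 nM in this assay. Of the two numbers, compound 3 stands at the lower one, but its gap to compound 1 lies within the usual scatter, so the two cannot be ranked against each other.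

Compound 4 `Nc1ccccc1NC(=O)c1ccc(COc2ccc(Cl)cc2)cc1` has not yet been measured. It differs from compound 3 in a single place: chloro in place of propyl on an aromatic carbon. The rest of the shared core, the amide and the aminophenyl group, is unchanged. Within the data shown here, no measured pair in this set shows what such an exchange does, so the expectation rests on the small size of the change and on the narrow spread of the two numbers seen so far. The step from compound 3 to compound 4 is expected to be a 1.0-fold higher number from compound 3 to compound 4 (0.01 log units; within the scatter), that is, no change beyond the scatter. Compound 4 is therefore estimated at 4500 nM, with a range from 1800 nM to 11000 nM.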

Compound 4, half-maximal inhibitory concentration: > 32000 nM
Compound 4: a limit, no number; the forecaster's own chance of this, stated with the estimate: 5%; at least 7.1-fold (0.85 log units) between middle value and limit.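

In this assay, this place on the ring, para to a large group, turns out not to tolerate every small exchange: chloro in place of propyl gives an at least 7.2-fold higher number from compound 3 to compound 4 (0.85 log units; beyond the scatter). The result for compound 4 is a limit of the assay and not a number: the limit of > 32000 nM in this assay, at which 1 of the 4 values shown sits. Among these compounds, compounds 1 and 3 differ in more than one place, so only this pair isolates the group at this position and shows that the choice of group there can matter to the read-out.

With only propyl and chloro compared here, the data cannot say which difference between the two groups matters, or how far the activity falls beyond the limit. A methyl, a longer chain, a methoxy group or an amine at this place would show whether the activity tracks the carbon chain or something else.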